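Working notes: from compound 3 to compound 4

This account rests on a few compounds, and the source may have more. Where it says the series, first, only, none or still open, it means among the compounds named here.

Measured so far in a functional assay on HT-29 cells (Homo sapiens) for cytotoxicity, read by sulforhodamine B assay; a higher number here means a weaker inhibitor of growth, a lower number a stronger inhibitor of growth:
- compound 1 `CC1=CC[C@@H]([C@@](C)(O)CCCC(C)(C)NC(=S)NN)CC1` gives 49400 nM
- compound 2 `COc1ccc(/C=N\NC(=S)NC(C)(C)CCC[C@](C)(O)[C@@H]2CC=C(C)CC2)cc1` gives 7420 nM
- compound 3 `CC1=CC[C@@H]([C@@](C)(O)CCCC(C)(C)NC(=S)N/N=C\c2ccc(O)cc2)CC1` gives 8150 nM

Compound 3 stands level with compound 2 within the scatter (a 1.1-fold higher number from compound 2 to compound 3 (0.04 log units; within the scatter)), and both lie well under compound 1 (a 6.1-fold lower number from compound 1 to compound 3 (0.78 log units; beyond the scatter)).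

Compound 4 `CC1=CC[C@@H]([C@@](C)(O)CCCC(C)(C)NC(=S)N/N=C\c2ccccc2[N+](=O)[O-])CC1` has not yet been measured. It differs from compound 3 by 2-nitrophenyl in place of 4-hydroxyphenyl on a carbon with a double bond to nitrogen.

Compound 2, compound 3 and compound 4 all carry an aromatic ring that compound 1 lacks. The modest steps from compound 1 (a 6.7-fold lower number from compound 1 to compound 2 (0.82 log units; beyond the scatter) and a 6.1-fold lower number from compound 1 to compound 3 (0.78 log units; beyond the scatter)) therefore bear on the ring as a whole, and compound 4 keeps that ring. The closest measured change on the ring itself, hydrogen in place of methyl on an oxygen, stayed within the scatter (a 1.1-fold higher number from compound 2 to compound 3 (0.04 log units; within the scatter)). Within the data shown here, no measured compound carries a nitro group, so the evidence for this swap is indirect and the range must stay wide.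

No step beyond the scatter is expected in this assay, and the estimate means a 1.3-fold lower number from compound 3 to compound 4 (0.10 log units; within the scatter) as the expected step.

For compound 4 the estimated value is 6500 nM with an expected range from 2500 nM to 17000 nM in this read-out.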

Compound 4, concentration for 50% growth inhibition: 6940 nM
Compound 4: middle estimate off by 1.1-fold (0.03 log units), on the low side; low and high end bracket the measured number.
By their numbers in this assay, from the lowest: compounds 4, 2 and 3 (each within the scatter of the next); then compound 1.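

In this assay, 2-nitrophenyl in place of 4-hydroxyphenyl on the carbon with a double bond to nitrogen gives a 1.2-fold lower number from compound 3 to compound 4 (0.07 log units; within the scatter), and 2-nitrophenyl in place of 4-methoxyphenyl gives a 1.1-fold lower number from compound 2 to compound 4 (0.03 log units; within the scatter). Compounds 2, 3 and 4 therefore stand level at this position, even though 2-nitrophenyl has no hydrogen-bond donor while 4-hydroxyphenyl has one, and the earlier pair had shown only the exchange of methyl for hydrogen on an oxygen. No independent measurement accounts for this levelness, so the result remains a description of the numbers alone.

The swap changes both the group and its place on the aromatic ring, so these two contributions cannot be separated among compounds 2, 3 and 4. The compounds shown also leave open whether an amine or a carboxylic acid on the aromatic ring, or a longer chain between the aromatic ring and the carbon with a double bond to nitrogen, would take the number beyond the scatter of this level.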